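Pyridyl methyl removal in a trifluoromethylpyrazole amide series

The source may report more compounds than this note shows. Statements on the series, on what has been measured and on what is new or still open speak of the compounds shown alone.

compound 1 `C[C@H](NC(=O)c1cc(C(F)(F)F)nn1C)c1nc(-c2cccc(F)c2)no1`: 136 nM
compound 2 `Cc1cc(-c2noc([C@H](C)NC(=O)c3cc(C(F)(F)F)nn3C)n2)ccn1`: 165 nM

In an assay on T-REx-293 cells for inhibition of potassium channel subfamily T member 1 (Homo sapiens), read by patch clamp (a lower number here means a stronger inhibitor, a higher number a weaker inhibitor), compound 2 gives 165 nM; on the numbers shown it sits together with compound 1, since the change a 1.2-fold higher number from compound 1 to compound 2 (0.08 log units; within the scatter) is within the scatter. Compound 3 `C[C@H](NC(=O)c1cc(C(F)(F)F)nn1C)c1nc(-c2ccncc2)no1` differs from compound 2 by hydrogen in place of methyl on an aromatic carbon, on an aromatic carbon next to the ring nitrogen, meta to a large group. Going by the values given here, no measured step touches this position; the only step in hand, the aryl swap, was within the scatter, so a step within the scatter is expected, a 1.2-fold higher number from compound 2 to compound 3 (0.08 log units; within the scatter). Compound 3 is expected to give 200 nM, range 100 nM to 450 nM.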

Compound 3, half-maximal inhibitory concentration: 5250 nM
Estimate against measurement, compound 3: 26-fold (1.42 log units) below; measured number outside the range, above it.
By their numbers in this assay, from the lowest: compounds 1 and 2 (each within the scatter of the next); then compound 3.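

In this assay hydrogen in place of the methyl of 2-methylpyridin-4-yl gives a 32-fold higher number from compound 2 to compound 3 (1.50 log units; beyond the scatter) and so this one methyl counts for far more than the aryl swap suggested. Pyridin-4-yl in place of 3-fluorophenyl gives a 39-fold higher number from compound 1 to compound 3 (1.59 log units; beyond the scatter) while a 1.2-fold higher number from compound 1 to compound 2 (0.08 log units; within the scatter) stays within the scatter, so among these compounds only the methylated pyridyl sits with 3-fluorophenyl. Nothing at hand explains the loss.

Going by these compounds, whether ethyl, methoxy or an amine on this carbon would keep the number close to that of compound 2 remains open. Also open, on these data alone, is whether the methyl counts as much with a different amide partner.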